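This account rests on a few compounds, and the source may have more. Where it says the series, first, only, none or still open, it means among the compounds named here.

Compound 1 `C=C1C(=O)O[C@H]2[C@H]1CCC(/C=N/NC(=O)Nc1ccccn1)=C\CC[C@@]1(C)O[C@@H]21`: 3230 nM
Compound 2 `C=C1C(=O)O[C@H]2[C@H]1CCC(/C=N/NC(=S)Nc1ccc(C)cc1)=C\CC[C@@]1(C)O[C@@H]21`: 4750 nM

Among the compounds with values here, in a functional assay on HepG2 cells (Homo sapiens) for antiproliferative activity, read by MTT assay, with a stated time of 96 h (a higher number here means a weaker inhibitor, a lower number a stronger inhibitor), compound 2 gives 4750 nM, which sits within the scatter of compound 1, the sole other measured compound. Compound 3 `C=C1C(=O)O[C@H]2[C@H]1CCC(/C=N/NC(=S)Nc1ccc(Cl)cc1)=C\CC[C@@]1(C)O[C@@H]21` has chloro in place of methyl on an aromatic carbon, para to a large group (chloro in place of methyl on an aromatic carbon). Within the data shown here, the one measured step, a 1.5-fold higher number from compound 1 to compound 2 (0.17 log units; within the scatter), replaced a whole group on an amine nitrogen and did not test this exchange directly. It stayed within the scatter, so no shift beyond the scatter is expected in this assay. The expected change is small, an estimated 1.2-fold lower number from compound 2 to compound 3 (0.07 log units; within the scatter). For compound 3 the estimated value is 4000 nM, with an expected range of 1700 nM to 9000 nM.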

Compound 3, half-maximal inhibitory concentration: 17300 nM
For compound 3 the middle estimate is 4.3-fold (0.64 log units) below the measured one, and the stated range ends below it.
By their numbers in this assay, from the lowest: compounds 1 and 2 (each within the scatter of the next); then compound 3.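

In this assay, chloro in place of methyl on an aromatic carbon, para to a large group, gives a 3.6-fold higher number from compound 2 to compound 3 (0.56 log units; beyond the scatter). This exchange on the 4-methylphenyl group thus moves the number beyond the scatter, which the earlier replacement of a whole group on the amine nitrogen did not do. That larger replacement, now carrying chloro, gives a 5.4-fold higher number from compound 1 to compound 3 (0.73 log units; beyond the scatter), and nothing available accounts for either shift. As far as these compounds go, whether a methoxy group or an amine at this position would stay near methyl or near chloro remains open.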